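A few compounds are considered here, and "the series" means these few. Any claim that something is new, unique, unknown or untested is made for them only; others in the source may bear on it.

Measured so far in a functional assay for inhibition of sodium/hydrogen exchanger (Oryctolagus cuniculus); a higher number here means a weaker inhibitor, a lower number a stronger inhibitor:
- compound 1, `Cc1cc(Br)c(S(C)(=O)=O)cc1C(=O)N=C(N)N`: 12 nM
- compound 2, `Cc1cc(C)c(S(C)(=O)=O)cc1C(=O)N=C(N)N`: 11 nM
- compound 3, `Cc1cc(-c2ccc(Cl)cc2Cl)c(S(C)(=O)=O)cc1C(=O)N=C(N)N`: 42 nM

Compound 3 gives the highest number of the three in this assay. Its nearest neighbour is compound 1, with a 3.5-fold higher number from compound 1 to compound 3 (0.54 log units; beyond the scatter) between them; the further one is compound 2, with a 3.8-fold higher number from compound 2 to compound 3 (0.58 log units; beyond the scatter). Compounds 1 and 2 differ only as a 1.1-fold lower number from compound 1 to compound 2 (0.04 log units; within the scatter) shows, so within this series the small bromo and methyl groups sit together at the stronger end, and the 2,4-dichlorophenyl group alone accounts for the modest weakening.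

Compound 4, `Cc1cc(Sc2ccc(Cl)cc2)c(S(C)(=O)=O)cc1C(=O)N=C(N)N`, is not yet measured. It differs from compound 3 as follows: (4-chlorophenyl)sulfanyl in place of 2,4-dichlorophenyl on an aromatic carbon. Both steps that bear on the position, the ones from compound 1 and from compound 2 to compound 3, concern the entry of a large aryl group in place of a single-atom substituent, and both were modest rises. For the measured compounds named here, compound 4 keeps a group of the same heavy-atom count at that position, and the series holds no step that separates a directly attached aryl ring from one joined through a sulfur. The expectation is therefore a number close to that of compound 3, with a 1.1-fold lower number from compound 3 to compound 4 (0.02 log units; within the scatter) expected to lie within the scatter. Compound 4 is estimated at 40 nM in this assay, with a range of 15 nM to 110 nM.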

Compound 4, half-maximal inhibitory concentration: 19 nM
Estimate against measurement, compound 4: 2.1-fold (0.32 log units) above; the range from low to high includes it.
By their numbers in this assay, from the lowest: compounds 2, 1 and 4 (each within the scatter of the next); then compound 3.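

In this assay, the step at this position, ortho to the methylsulfonyl group, is a modest one (a 2.2-fold lower number from compound 3 to compound 4 (0.34 log units; beyond the scatter)), so two groups with the same heavy-atom count and one six-membered aromatic ring of carbon only are still told apart, and the heavy-atom count alone does not fix the number here. The earlier steps shown here tied a large aryl group to a modest rise, but the (4-chlorophenyl)sulfanyl group stays within the scatter of both small groups (a 1.7-fold higher number from compound 2 to compound 4 (0.24 log units; within the scatter); a 1.6-fold higher number from compound 1 to compound 4 (0.20 log units; within the scatter)), so the rise seen with compound 3 does not extend to every group of this size at this position. No measurement among the data speaks to the reason for this difference.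

On these data alone, the change from compound 3 to compound 4 alters both the sulfur link and the chlorine pattern, so it remains open whether either alone carries the step, which a directly attached 4-chlorophenyl or a (2,4-dichlorophenyl)sulfanyl group would separate. Also open, as far as these compounds go, is how an oxygen link, as in 4-chlorophenoxy, or an amine at this position would read in this assay.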